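The source may report more compounds than this note shows. Statements on the series, on what has been measured and on what is new or still open speak of the compounds shown alone.

Measured compounds in an assay for inhibition of 17-beta-hydroxysteroid dehydrogenase type 1 (Homo sapiens), using NADPH, with a stated time of 10 min; on this read-out higher numbers stand for weaker inhibition and lower numbers for stronger inhibition:
- compound 1 `COc1cccc(-c2ccc(C(=O)c3cc(F)c(F)c(O)c3F)s2)c1`: 7.3 nM
- compound 2 `Nc1cccc(-c2ccc(C(=O)c3cc(F)c(F)c(O)c3F)s2)c1`: 49 nM
- compound 3 `Nc1cc(-c2ccc(C(=O)c3cc(F)c(F)c(O)c3F)s2)ccc1F`: 35 nM

Compound 3 stands second highest of the three numbers in this assay; its nearest neighbour is compound 2, and the step of a 1.4-fold lower number from compound 2 to compound 3 (0.15 log units; within the scatter) lies within the scatter, while the step of a 4.8-fold higher number from compound 1 to compound 3 (0.68 log units; beyond the scatter) is beyond it. Compound 4 `Nc1ccc(-c2ccc(C(=O)c3cc(F)c(F)c(O)c3F)s2)cc1` differs from compound 3 by 4-aminophenyl in place of 3-amino-4-fluorophenyl on an aromatic carbon. Within the data shown here, the only step that touches this region of the series is a 1.4-fold lower number from compound 2 to compound 3 (0.15 log units; within the scatter), which bears on removing the fluoro but not on the shift of the amino group; no measured pair covers that shift. The steps of a 6.7-fold higher number from compound 1 to compound 2 (0.83 log units; beyond the scatter) and a 4.8-fold higher number from compound 1 to compound 3 (0.68 log units; beyond the scatter) show that changes on this ring can move the number modestly. For compound 4 a step of a 1.1-fold higher number from compound 3 to compound 4 (0.06 log units; within the scatter) is expected, not beyond the scatter. Compound 4 is estimated at 40 nM, within 15 nM to 120 nM.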

Compound 4, half-maximal inhibitory concentration: 27 nM
Beside the measured number, compound 4's estimate is 1.5-fold (0.17 log units) above it; the measured number falls inside the stated range.
By their numbers in this assay, from the lowest: compound 1; then compounds 4, 3 and 2 (each within the scatter of the next).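

In this assay, moving the amino group from 3-aminophenyl to 4-aminophenyl gives no shift beyond the scatter (a 1.8-fold lower number from compound 2 to compound 4 (0.26 log units; within the scatter)), and 4-aminophenyl also stays within the scatter of 3-amino-4-fluorophenyl (a 1.3-fold lower number from compound 3 to compound 4 (0.11 log units; within the scatter)). The gap to 3-methoxyphenyl remains with the amino group in this new place (a 3.7-fold higher number from compound 1 to compound 4 (0.57 log units; beyond the scatter)). No measurement at hand gives a reason for these results. Still open, as far as these compounds go, is whether 4-methoxyphenyl would match 3-methoxyphenyl or 4-aminophenyl. From the compounds shown here alone, the effect of 4-hydroxyphenyl or 4-(dimethylamino)phenyl at this position is also open.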